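A few compounds are considered here, and "the series" means these few. Any claim that something is new, unique, unknown or untested is made for them only; others in the source may bear on it.

Series notes. Of the compounds shown here, three on the shared core have been measured: compound 1 `O=C1/C(=C/c2ccccc2Cl)CCc2ccc(O)cc21`, compound 2 `O=C1/C(=C/c2ccc(Cl)cc2)CCc2ccc(O)cc21` and compound 3 `O=C1/C(=C/c2ccccc2Br)CCc2ccc(O)cc21`. Compound 4 `O=C1/C(=C/c2ccc(Br)cc2)CCc2ccc(O)cc21` has not yet been measured.

In a functional assay on RAW264.7 cells (Mus musculus) for inhibition (a higher number here means a weaker inhibitor, a lower number a stronger inhibitor), compound 1 gives 270 nM. In this assay compound 3 gives 500 nM. In this assay compound 2 gives 1100 nM, the highest number of the three.

The change from compound 1 to compound 3 is bromo in place of chloro on an aromatic carbon, and the step it made was a 1.9-fold higher number from compound 1 to compound 3 (0.27 log units; within the scatter). The difference between the cores of compound 1 and compound 2 is not broken down here; the two have the same atoms joined differently.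

The change from compound 2 to compound 4 is bromo in place of chloro on an aromatic carbon. It is the same kind of change as from compound 1 to compound 3, but the place differs: ortho to a large group in the first pair, para to a large group in the second.

Beside the earlier step of a 1.9-fold higher number from compound 1 to compound 3 (0.27 log units; within the scatter), the step expected from compound 2 to compound 4 is a 1.5-fold higher number from compound 2 to compound 4 (0.19 log units; within the scatter), resting on the step that the same kind of change made from compound 1 to compound 3, a 1.9-fold higher number from compound 1 to compound 3 (0.27 log units; within the scatter). For compound 4 in this assay the expected value is 1700 nM, between 800 nM and 4000 nM.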

Compound 4, half-maximal inhibitory concentration: 800 nM
For compound 4 the middle estimate is 2.1-fold (0.33 log units) above the measured one, within the range that was stated.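

In this assay, bromo in place of chloro on an aromatic carbon, para to a large group, gives a 1.4-fold lower number from compound 2 to compound 4 (0.14 log units; within the scatter), so compound 4 cannot be told apart from compound 2. Set beside the same change ortho to a large group, the two steps do not differ by more than two such steps normally scatter: the same change on two cores in this assay, a 1.9-fold higher number (0.27 log units; within the scatter) from compound 1 to compound 3 and a 1.4-fold lower number (0.14 log units; within the scatter) from compound 2 to compound 4, 2.5-fold (0.41 log units) apart, within the scatter of two such steps. This gives no sign that the exchange behaves differently between the two pairs, but it does not show that the steps are equal, and with both steps this small neither their size nor their direction is settled, so it offers no firm value to carry to another core.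

The compounds shown carry only chloro and bromo on the six-membered aromatic ring, so it stays open how the values run with a methoxy group, an amine or a carboxylic acid there. Also open, from the compounds shown here alone, is whether the exchange holds when the hydroxyl on the shared core is replaced by a methoxy group.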